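This account rests on a few compounds, and the source may have more. Where it says the series, first, only, none or still open, it means among the compounds named here.

In a functional assay on QGY cells (Homo sapiens) for cytotoxicity, read by MTT assay, with a stated time of 48 h (on this read-out lower numbers stand for stronger inhibition and higher numbers for weaker inhibition), compound 1 (`COc1cc([C@@H]2C[C@@]2(CO)C(=O)Nc2ccccc2)cc(OC)c1OC`) gives 36700 nM. Compound 3 (`COc1cc([C@@H]2C[C@@]2(CO)C(=O)Nc2ccccc2Cl)cc(OC)c1OC`) gives 24500 nM, and the chloro group behind a 1.5-fold lower number from compound 1 to compound 3 (0.18 log units; within the scatter) leaves the two numbers within the usual scatter of each other. Compound 2 (`COc1cc([C@H]2C[C@]2(CO)C(=O)Nc2ccccc2)cc(OC)c1OC`) is the mirror image of compound 1. Compound 2 gives > 100000 nM, which is a limit of the assay and not a number. That limit is also what bounds an at least 2.7-fold higher number from compound 1 to compound 2 (0.43 log units; beyond the scatter), whose only structural basis is the fact that compounds 1 and 2 differ only in the configuration as drawn.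

Compound 4 (`CCOC(=O)[C@@]1(C(=O)Nc2ccccc2)C[C@H]1c1cc(OC)c(OC)c(OC)c1`) has ethoxycarbonyl in place of hydroxymethyl on a saturated ring carbon. Going by the values given here, no measured step swaps this group, so the evidence is indirect. The chloro change in compound 3, at 24500 nM, lies elsewhere on the molecule and says little here. Compound 2 matters more, since an at least 2.7-fold higher number from compound 1 to compound 2 (0.43 log units; beyond the scatter) involves inversion at this same ring carbon and shows that the number can respond to changes there. On that thin basis, a small move towards weaker inhibition seems more likely than a move towards stronger inhibition, and it may not clear the scatter. The expected change is a 1.5-fold higher number from compound 1 to compound 4 (0.18 log units; within the scatter). For compound 4 the estimated value is 55000 nM, with an expected range from 18000 nM to 100000 nM.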

Compound 4, half-maximal inhibitory concentration: 48700 nM
Beside the measured number, compound 4's estimate is 1.1-fold (0.05 log units) above it; measured number inside the range.
By their numbers in this assay, from the lowest: compounds 3, 1 and 4 (each within the scatter of the next). At a limit, above all of these: compound 2.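

Ethoxycarbonyl in place of hydroxymethyl gives a 1.3-fold higher number from compound 1 to compound 4 (0.12 log units; within the scatter) in this assay and so adds the first direct reading of a group swap at this saturated ring carbon, where the earlier compounds showed only what inverting the configuration does. The group that enters has more heavy atoms than hydroxymethyl and no hydrogen-bond donor, yet the two numbers cannot be told apart, so at this position the read-out accepts a larger group and does not need that donor to stay at this level. Nothing measured here explains why these two different groups give such similar numbers.

From the compounds shown here alone, it remains open whether this tolerance reaches other groups on the same ring carbon, such as a carboxylic acid, an aminomethyl group or a longer chain like a butyl ester, or whether any of them would move the number beyond the scatter. Also open, going by these compounds, is whether ethoxycarbonyl would behave the same way alongside the chloro group of compound 3, since the two changes appear here only on separate molecules.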